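A few compounds are considered here, and "the series" means these few. Any claim that something is new, unique, unknown or untested is made for them only; others in the source may bear on it.

Measured so far in an ADME assay on cells (Hepatocyte, Canis lupus familiaris) for metabolic stability, read by LC-MS; on this read-out lower numbers stand for slow clearance and higher numbers for fast clearance:

- compound 1, `CNC(=O)c1cc(C(=O)N[C@H]2CC[C@H](O)CC2)c([C@@H](C)c2cccc(Cl)c2)o1`: 0.71 mL/min
- compound 2, `CNC(=O)c1cc(C(=O)N[C@H]2CC[C@H](O)CC2)n([C@@H](C)c2ccccc2)n1`: < 0.7 mL/min
- compound 3, `CNC(=O)c1cc(C(=O)N[C@H]2[C@@H]3COC[C@@H]32)c([C@@H](C)c2ccccc2)o1`: < 0.65 mL/min

Compound 2 gives < 0.7 mL/min, which is a limit of this assay, not a number, as set out in the limit of < 0.7 mL/min in this assay, at which 1 of the 3 values shown sits. Compound 3 likewise sits at a limit of this assay, (the limit of < 0.65 mL/min in this assay, at which 1 of the 3 values shown sits). Compound 1 alone gives a real number, and it sits close to both limits. Compound 2 therefore stands at the low end of what this assay resolves here.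

Compound 4, `CNC(=O)c1cc(C(=O)N[C@H]2CC[C@H](OC)CC2)n([C@@H](C)c2ccccc2)n1`, differs from compound 2 by methyl in place of hydrogen on an oxygen on a saturated carbon, hydroxy to methoxy on the cyclohexyl amide. Among the compounds with values here, no measured step of this kind exists in the set. The expected step of an at least 1.4-fold higher number from compound 2 to compound 4 (0.15 log units; that floor lies within the scatter) is small, upward if anything, and may stay within the scatter. For compound 4 the estimate is 1 mL/min, in the range 0.5 mL/min to 2.5 mL/min.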

Compound 4, intrinsic clearance in a liver preparation (reported as CLH), per the amount of preparation that the assay uses in the Hepatocyte assay: < 0.65 mL/min
Compound 4 was reported as a limit; the forecaster's own chance of this, stated with the estimate: 35%; middle value at least 1.5-fold (0.18 log units) from the limit.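

Within the data shown here, compound 2 and compound 4 both sit at limits in the Hepatocyte assay, so no step between them can be read there or in a physicochemical assay for solubility; on this read-out higher numbers stand for higher solubility and lower numbers for lower solubility. In the physicochemical assay compound 2 gives >= 180 ug/mL, a limit. In the physicochemical assay compound 4 gives >= 161 ug/mL, also a limit. As far as these compounds go, what 4-hydroxycyclohexyl to 4-methoxycyclohexyl does to either read-out stays open.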